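The source may hold more compounds than are shown below. What is called first, only, known or untested is meant among the compounds shown, and "the series" means these compounds.

Working notes on the series. In a functional assay on SK-MEL-2 cells (Homo sapiens) for inhibition, read by sulforhodamine B assay, with a stated time of 48 h (on this read-out higher numbers stand for lower toxicity in this test and lower numbers for higher toxicity in this test), compound 1 `Nc1cc(N)c2nc(-c3ccccc3)c(NCc3ccc(Cl)c(Cl)c3)nc2c1` gives 9550 nM. Compound 2 `COc1ccc(CNc2nc3cc(N)cc(N)c3nc2-c2ccccc2)cc1OC` gives only a limit in this assay, namely < 100000 nM, so it stands on a limit and not on a number. The step that the limit leaves unreadable from compound 1 to compound 2 stays unreadable because of the limit of < 100000 nM in this assay, at which 1 of the 2 values shown sits. Compound 3 `COc1cc(CNc2nc3cc(N)cc(N)c3nc2-c2ccccc2)cc(OC)c1OC` carries methoxy in place of hydrogen on an aromatic carbon. Within the data shown here, no measured step reports a methoxy added in this way, and the only neighbouring step is unreadable, so no size or direction beyond the scatter can be expected in this assay. Compound 3 is therefore estimated near compound 2, at 40000 nM with a range of 8000 nM to 100000 nM. The step that the limit leaves unreadable from compound 2 to compound 3 is expected.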

Compound 3, concentration lethal to 50% of the cells: < 50200 nM
Compound 3: a limit, no number (the forecaster's own chance of this, stated with the estimate: 40%); the middle value does not contradict the limit.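

Among these compounds, compound 2 and compound 3 each stand on a limit and not on a number, and no step between them can be read. The compounds shown leave open whether methoxy in place of hydrogen on an aromatic carbon shifts the read-out, in either direction.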